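The source may report more compounds than this note shows. Statements on the series, on what has been measured and on what is new or still open speak of the compounds shown alone.

Measured so far in a functional assay on the whole organism with Mus musculus as the target; a lower number here means that less compound is needed, a higher number that more compound is needed for the effect:
- compound 1 `NC(=O)/C=C1\CCc2c(F)cccc21`: > 100 mg/kg (a limit)
- compound 2 `O=C(/C=C1\CCc2c(F)cccc21)NC1CC1`: 126 mg/kg

Compound 1 gives > 100 mg/kg, which is a limit and not a number. This gives the starting point only as a bound, not as an exact dose.

Compound 3 `NC(=O)/C=C1\CCc2c1ccc(F)c2F` keeps the core of compound 1 and makes one change: fluoro in place of hydrogen on an aromatic carbon, ortho to a fluoro group (fluoro in place of hydrogen on an aromatic carbon).

For the measured compounds named here, only one measured step exists, a step that the limit leaves unreadable from compound 1 to compound 2. It concerns cyclopropyl in place of hydrogen on an amide-type nitrogen, not a change on the aromatic carbon, so it offers no size or direction to carry over.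

With no measured guide, no shift beyond the scatter is expected in this assay, and the expected step is an at least 1.1-fold lower number from compound 1 to compound 3 (0.04 log units; that floor lies within the scatter). For compound 3 the estimate is 90 mg/kg, with an expected range from 35 mg/kg to 220 mg/kg.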

Compound 3, dose for half-maximal effect: 45 mg/kg
Beside the measured number, compound 3's estimate is 2.0-fold (0.30 log units) above it, and the stated range covers the measured number.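

In this assay, for the compounds shown here, a second fluoro on the aromatic ring, ortho to the first fluoro group, gives an at least 2.2-fold lower number from compound 1 to compound 3 (0.34 log units; beyond the scatter), which makes this the first change with a readable direction and shows that this position can move the dose needed. The earlier step, at the amide nitrogen, could not be read, so it said nothing about the aromatic ring. The size of the new step is only a floor, and the real difference may be larger: the limit of > 100 mg/kg in this assay, at which 1 of the 3 values shown sits.

On these data alone, whether a chloro, methyl or methoxy group at this same place would lower the number as well remains open. Also open, as far as these compounds go, is whether the second fluoro would have the same effect alongside the cyclopropyl group on the amide nitrogen of compound 2.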